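Removing a Chloro Group from the Strongest Binder

The source may report more compounds than this note shows. Statements on the series, on what has been measured and on what is new or still open speak of the compounds shown alone.

Compound 1 `Clc1ccc(-c2cnc3cc4c(cc3n2)C2CNCC4C2)c(Cl)c1` gives 88 nM in an assay for binding affinity to Neuronal acetylcholine receptor; alpha4/beta2 (Rattus norvegicus); a higher number here means a weaker inhibitor, a lower number a stronger inhibitor.
Compound 2 `CCc1nc2cc3c(cc2o1)C1CNCC3C1` gives 12 nM in this assay.
Compound 3 `Clc1ccc2cc3c(cc2n1)C1CNCC3C1` gives 0.27 nM in this assay.

Among these three, compound 3 stands lowest in this assay; compound 2 gives a clearly higher number and compound 1 a higher one still, both gaps beyond the usual scatter, so compound 3 is the most potent of the set. Compound 4 `c1cnc2cc3c(cc2c1)C1CNCC3C1` differs from compound 3 in one place: hydrogen in place of chloro on an aromatic carbon. Among the compounds with values here, no measured pair here isolates this change, so its effect cannot be read from the data. A modest loss of affinity is expected, a step of a 7.4-fold higher number from compound 3 to compound 4 (0.87 log units; beyond the scatter), since the only single-atom difference from the strongest compound is removed. Compound 4 is therefore estimated at 2 nM, with a range from 0.5 nM to 10 nM.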

Compound 4, inhibition constant: 1.6 nM
Estimate against measurement, compound 4: 1.3-fold (0.10 log units) above; the range from low to high includes it.
By their numbers in this assay, from the lowest: compound 3; then compound 4; then compound 2; then compound 1.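

Swapping chloro for hydrogen on the aromatic carbon next to the ring nitrogen gives a 5.9-fold higher number from compound 3 to compound 4 (0.77 log units; beyond the scatter) in this assay, the first pair here in which a single change can be read. At this place, chloro therefore gives a stronger binder than hydrogen, although compound 4 still reaches 1.6 nM without it. As far as these compounds go, whether fluoro, methyl, methoxy or an amine here would give a number closer to that of compound 3 or compound 4 remains open. Nothing available here accounts for the size of this step.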